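Oxazole to pyridine on the acid-bearing chain carbon

The source may report more compounds than this note shows. Statements on the series, on what has been measured and on what is new or still open speak of the compounds shown alone.

Of the compounds shown here, three have been measured in a functional assay on HEK293 cells for agonist activity at Free fatty acid receptor 1 (Homo sapiens), read by fluorescence and calcium flux, with a stated time of 10 min; on this read-out higher numbers stand for an effect only at larger amounts of compound and lower numbers for an effect already at smaller amounts. Compound 1 `O=C(O)CCc1ccc(OCC2COc3ccc(Cl)cc3O2)cc1F` gives 830 nM, compound 2 `O=C(O)CCc1ccc(NCC2COc3ccc(Cl)cc3O2)cc1F` gives 13600 nM, and compound 3 `O=C(O)CC(c1ccc(OCC2COc3ccc(Cl)cc3O2)cc1)c1cnco1` gives 1030 nM. Compound 3 therefore holds the second highest of the three numbers: compound 1 lies nearest, within the usual scatter, while compound 2 lies furthest, with a higher number that falls beyond the scatter.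

Compound 4 `O=C(O)CC(c1ccncc1)c1ccc(OCC2COc3ccc(Cl)cc3O2)cc1` differs from compound 3 in one place: pyridin-4-yl in place of 1,3-oxazol-5-yl on a saturated chain carbon bound to an aromatic carbon and a saturated chain carbon. Among the compounds with values here, no measured pair in this set shows the effect of such a swap on the acid-bearing chain carbon, so the direction of the step is open. Since both aromatic groups are small, neutral, and carry only acceptors, no step beyond the scatter is expected in this assay , and the estimated step from compound 3 to compound 4 is a 1.0-fold lower number from compound 3 to compound 4 (0.01 log units; within the scatter). Compound 4 is accordingly expected to give about 1000 nM, in a range from 350 nM to 3000 nM.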

Compound 4, half-maximal effective concentration: 1170 nM
Compound 4: the middle estimate sits 1.2-fold (0.07 log units) below what was measured; measured number inside the range.
By their numbers in this assay, from the lowest: compounds 1, 3 and 4 (each within the scatter of the next); then compound 2.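

In this assay, placing pyridin-4-yl in place of 1,3-oxazol-5-yl on a saturated chain carbon bound to an aromatic carbon and a saturated chain carbon gives a 1.1-fold higher number from compound 3 to compound 4 (0.06 log units; within the scatter). Within the data shown here, this is the first pair in the set that differs only at this carbon, and it shows that the read-out does not separate a five-membered aromatic ring with 2 hetero atoms from a six-membered aromatic ring with 1 hetero atom here. Nothing available offers an explanation for this outcome.

The compounds shown leave open whether a group that is not an aromatic ring, such as a methyl group or an amine, would hold the number at this carbon. They also leave open how a plain phenyl or a pyridin-3-yl would compare with pyridin-4-yl there.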